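The source may hold more compounds than are shown below. What is called first, only, known or untested is meant among the compounds shown, and "the series" means these compounds.

Working notes on the series. Compound 1 `c1ccc(-c2ccncc2)c(OCC2=NCCN2)c1` carries the core shared by compound 2 `c1cnc(-c2ccccc2OCC2=NCCN2)nc1`, compound 3 `Cc1ccoc1-c1ccccc1OCC1=NCCN1` and the unmeasured compound 4 `Cn1nccc1-c1ccccc1OCC1=NCCN1`. In a functional assay for activation of Alpha-1B adrenergic receptor (Homo sapiens), read by calcium flux (a lower number here means that less compound is needed, a higher number that more compound is needed for the effect), compound 1 gives only a limit of < 100000 nM. Compound 2 likewise gives a limit, < 100000 nM. Compound 3 also gives a limit, < 100000 nM. The steps among them, a step that the two limits leave unreadable from compound 1 to compound 2, a step that the two limits leave unreadable from compound 1 to compound 3 and a step that the two limits leave unreadable from compound 2 to compound 3, therefore cannot be sized, since (the limit of < 100000 nM in this assay, at which 3 of the 3 values shown sit).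

The change to compound 4 is 1-methyl-1H-pyrazol-5-yl in place of pyridin-4-yl on an aromatic carbon. The steps that touch the same position, exchange of one aromatic group for another, are all unreadable, so no direction or size can be drawn from them; the only ground is that every measured compound sits at the limit. Compound 4 is accordingly expected at 30000 nM, with a range from 2000 nM to 100000 nM, and most likely as a limit again. The step this estimate implies, a step that the limit leaves unreadable from compound 1 to compound 4, is expected to be small.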

Compound 4, half-maximal effective concentration: < 100000 nM
Compound 4 gave a limit, no number (the forecaster's own chance of this, stated with the estimate: 70%); the middle value lies beyond the limit too.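

Compound 4 gives only a limit, < 100000 nM. Its steps to compound 1, compound 2 and compound 3 therefore cannot be read: the limit of < 100000 nM in this assay, at which 4 of the 4 values shown sit.

The compounds shown leave open whether exchanging one aromatic group for another on the shared core changes the concentration needed in this assay, and in which direction.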